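This account rests on a few compounds, and the source may have more. Where it says the series, first, only, none or still open, it means among the compounds named here.

Compound 1 `O=c1ccoc(/C=C/c2ccccc2)c1` and compound 2 `COc1ccc(/C=C/c2cc(=O)cco2)cc1` share one core; compound 3 `COc1ccc(/C=C/C2CC=CC(=O)O2)cc1` carries another, and the difference between the two cores is not broken down here. In an ADME assay on HaCaT cells (Homo sapiens) for inhibition, read by sulforhodamine B assay, with a stated time of 48 h (on this read-out higher numbers stand for weaker inhibition of growth and lower numbers for stronger inhibition of growth), compound 1 gives 711 uM and compound 2 gives 710 uM; the step of a 1.0-fold lower number from compound 1 to compound 2 (0.00 log units; within the scatter) rests on the change (methoxy in place of hydrogen on an aromatic carbon). In this assay compound 3 gives 58.8 uM. Compound 4 `COc1ccc(/C=C/C2CC=CC(=O)O2)c(OC)c1` follows from compound 3 by methoxy in place of hydrogen on an aromatic carbon. This is the same kind of change as from compound 1 to compound 2, but the place differs: there the methoxy sits para to a group of 9 heavy atoms, here ortho to a group of 9 heavy atoms and meta to a methoxy group. Because the earlier step of a 1.0-fold lower number from compound 1 to compound 2 (0.00 log units; within the scatter) lay within the scatter, the step from compound 3 to compound 4 is expected to be a 1.1-fold lower number from compound 3 to compound 4 (0.03 log units; within the scatter). Compound 4 is estimated at 55 uM, between 25 uM and 130 uM.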

Compound 4, concentration for growth inhibition (reported as GI): 15.8 uM
Beside the measured number, compound 4's estimate is 3.5-fold (0.54 log units) above it, and the stated range ends above it.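

In this assay, methoxy in place of hydrogen on an aromatic carbon gives a 3.7-fold lower number from compound 3 to compound 4 (0.57 log units; beyond the scatter). Set beside the earlier step, the same change did not keep its size from one core to the other: the same change on two cores in this assay, a 1.0-fold lower number (0.00 log units; within the scatter) from compound 1 to compound 2 and a 3.7-fold lower number (0.57 log units; beyond the scatter) from compound 3 to compound 4, 3.7-fold (0.57 log units) apart, beyond the scatter of two such steps. This does not separate core from place: in compound 4 the methoxy stands ortho to a group of 9 heavy atoms and meta to a methoxy group, a placement that differs from the earlier step, and two steps give no rule for the series.

Open, as far as these compounds go, is whether this placement on the core of compound 1 would give a similar step. Also open, from the compounds shown here alone, is how a hydroxy group, an amine or a longer alkoxy chain at the same place would read in this assay.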